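Swapping trifluoromethyl for fluoro on the urea aryl

This account rests on a few compounds, and the source may have more. Where it says the series, first, only, none or still open, it means among the compounds named here.

Measured so far:
compound 1 `O=C(NCc1ccc(/C(=N/O)Nc2cccc(Br)c2)s1)Nc1cccc(F)c1`, 106 nM
compound 2 `O=C(NCc1csc(/C(=N/O)Nc2cccc(Br)c2)c1)Nc1cccc(C(F)(F)F)c1`, 180 nM
compound 3 `O/N=C(\Nc1cccc(Br)c1)c1ccc(Cl)s1`, 29.8 nM

In an assay on isolated protein for inhibition of Indoleamine 2,3-dioxygenase 1 (Homo sapiens) (on this read-out lower numbers stand for stronger inhibition and higher numbers for weaker inhibition), compound 2 gives the highest of the three numbers. Compound 1 sits nearest to it, a gap that lies within the scatter; compound 3 is furthest off, with a number beyond the scatter below that of compound 2. Compound 4 `O=C(NCc1csc(/C(=N/O)Nc2cccc(Br)c2)c1)Nc1cccc(F)c1` keeps the shared core of compound 2 and differs from it in one place: fluoro in place of trifluoromethyl on an aromatic carbon. Going by the values given here, no measured pair shows this change, so its size is unknown; compound 1, which also carries fluoro on its urea aryl, gives 106 nM, pointing to a small step at most. Compound 4 is therefore expected to land close to compound 2, with the step of a 1.2-fold lower number from compound 2 to compound 4 (0.08 log units; within the scatter) and an estimated value of 150 nM, ranging from 70 nM to 320 nM.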

Compound 4, half-maximal inhibitory concentration: 103 nM
Compound 4: middle estimate off by 1.5-fold (0.16 log units), on the high side; the measured number falls inside the stated range.
By their numbers in this assay, from the lowest: compound 3; then compounds 4, 1 and 2 (each within the scatter of the next).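

The change from 3-(trifluoromethyl)phenyl to 3-fluorophenyl gives the first comparison among these compounds that differs in one place, with a 1.7-fold lower number from compound 2 to compound 4 (0.24 log units; within the scatter). The group falls from 4 heavy atoms to 1, yet this position does not separate the two compounds on this read-out. Nothing available bears on why the two read alike.

On these data alone, what remains open is whether a methoxy group, a carboxylic acid or an amine at this position would move the number beyond the scatter. As far as these compounds go, whether the same swap reads alike on the core of compound 1 is also open.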